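Adding a Second Methoxy to Compound 2

The source may report more compounds than this note shows. Statements on the series, on what has been measured and on what is new or still open speak of the compounds shown alone.

Of the compounds shown here, three built on one shared core have been measured in a functional assay on HL-60 cells (Homo sapiens) for cytotoxicity, read by WST assay, with a stated time of 48 h; on this read-out higher numbers stand for an effect only at larger amounts of compound and lower numbers for an effect already at smaller amounts. There, compound 1 `O=C1OC[C@H](Cc2ccccc2)[C@H]1Cc1ccc(Cl)c(Cl)c1` gives 19000 nM, compound 2 `COc1ccc(C[C@H]2COC(=O)[C@@H]2Cc2ccc(Cl)c(Cl)c2)cc1` gives 37000 nM and compound 3 `Cc1ccc(C[C@H]2COC(=O)[C@@H]2Cc2ccc(Cl)c(Cl)c2)cc1` gives 19000 nM. Compound 2 cannot be told apart from either of the others, since its value lies within the usual scatter of both.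

Compound 4 `COc1ccc(C[C@H]2COC(=O)[C@@H]2Cc2ccc(Cl)c(Cl)c2)cc1OC` comes from compound 2 through a single change: methoxy in place of hydrogen on an aromatic carbon. This is methoxy in place of hydrogen on an aromatic carbon, ortho to a methoxy group and meta to a large group.

Among the compounds with values here, three measured steps bear on this change. Methoxy in place of hydrogen on an aromatic carbon gave a 1.9-fold higher number from compound 1 to compound 2 (0.29 log units; within the scatter). Methyl in place of hydrogen gave no change at the digits printed from compound 1 to compound 3 (within the scatter), and methyl in place of methoxy gave a 1.9-fold lower number from compound 2 to compound 3 (0.29 log units; within the scatter). All three stay within the scatter. Within the data shown here, no measured compound carries a second group of this kind, so the comparison is indirect. On this evidence, no step beyond the scatter is expected, and the expected step is a 1.2-fold lower number from compound 2 to compound 4 (0.09 log units; within the scatter). In this assay, compound 4 is estimated at 30000 nM, with an expected range from 14000 nM to 65000 nM.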

Compound 4, half-maximal effective concentration: 24000 nM
For compound 4 the middle estimate is 1.3-fold (0.10 log units) above the measured one, and the stated range covers the measured number.
By their numbers in this assay, from the lowest: compounds 1, 3, 4 and 2 (each within the scatter of the next).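

In this assay, a second methoxy, ortho to a methoxy group and meta to a large group, gives a 1.5-fold lower number from compound 2 to compound 4 (0.19 log units; within the scatter), so compound 2 and compound 4 cannot be told apart at this position. Compound 1, compound 2 and compound 3 each carry at most one group on this six-membered aromatic ring, which makes compound 4 the first case here of a second group on it, and the number still stays within the scatter of compound 2. Nothing available here offers an explanation for this result.

The compounds shown leave open whether any group on this ring can move the number beyond the scatter at all, as every step seen so far stays within it. An amine or a carboxylic acid at this same position, or a longer chain such as butoxy in place of the new methoxy, remains an open case, and so does the question of whether a second methoxy would read the same way at another place on the ring.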